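Tolerated concentrations along a short amide series

This account rests on a few compounds, and the source may have more. Where it says the series, first, only, none or still open, it means among the compounds named here.

compound 1 `COc1ccc(-c2cnc(NC(=O)c3ccc(O)cc3)n2C)cc1`: > 100000 nM
compound 2 `COc1ccc(-c2cnc(NC(=O)c3cnco3)n2C)cc1`: > 100000 nM

In a toxicity assay on THP-1 cells (Homo sapiens) for inhibition (a lower number here means that less compound is tolerated, a higher number that more compound is tolerated), compound 1 reaches only the limit of the assay, reported as > 100000 nM. In this assay compound 2 likewise reaches only the limit, reported as > 100000 nM. Going by the values given here, the one measured step, a step that the two limits leave unreadable from compound 1 to compound 2, therefore cannot be read, since (the limit of > 100000 nM in this assay, at which 2 of the 2 values shown sit). Compound 2 thus stands at the top of what the assay can report, with no number beneath it.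

Compound 3 `COc1ccc(-c2cnc(NC(=O)c3cccc(C)c3)n2C)cc1` is not yet measured and differs from compound 2 in one place: 3-methylphenyl in place of 1,3-oxazol-5-yl on a carbonyl carbon.

Among the compounds with values here, the only measured step bears on this change merely by showing that both its compounds sit at the limit, so no size or direction can be drawn from it. Compound 3 is expected to remain near that limit, with a step of a number no higher from compound 2 to compound 3 (the limit leaves the size open) that is expected to lie within the scatter. The estimate for compound 3 in this assay is 100000 nM, expected between 30000 nM and 300000 nM.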

Compound 3, half-maximal cytotoxic concentration: > 100000 nM
Compound 3: a limit, no number; the forecaster's own chance of this, stated with the estimate: 70%; the middle value lies on the limit itself.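

Compound 3 also reaches only a limit, so the steps to it from compound 1 and compound 2 cannot be read: the limit of > 100000 nM in this assay, at which 3 of the 3 values shown sit. Left open is whether compound 1, compound 2 and compound 3 differ at all in this assay and at what concentration each would become cytotoxic.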